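The source may report more compounds than this note shows. Statements on the series, on what has been measured and on what is new or still open speak of the compounds shown alone.

Working notes on the series, read in an in vitro ADME assay on microsomes from liver (Homo sapiens) for pharmacokinetics, read by LC-MS, with a stated time of 10 min, tested at 1 uM; a higher number here means faster removal of the compound, a lower number slower removal. Within the data shown here, compound 1 `CN1C[C@H](C(=O)Nc2ccc(C3CC3)cc2)[C@@H](c2ccc(/C=C/C(=O)Nc3ccccc3N)cc2)C1` gives 12 mL/min/kg and compound 2 `Cc1cccc(NC(=O)[C@H]2CN(C)C[C@@H]2c2ccc(/C=C/C(=O)Nc3ccccc3N)cc2)c1` gives 14 mL/min/kg, so compound 2 stands within the scatter of the only other measured compound. Next is compound 3 `CN1C[C@H](C(=O)Nc2ccc(F)c(Cl)c2)[C@@H](c2ccc(/C=C/C(=O)Nc3ccccc3N)cc2)C1`, which differs from compound 2 by 3-chloro-4-fluorophenyl in place of 3-methylphenyl on an amide-type nitrogen. Among the measured compounds shown here, the only measured step bearing on this change is a 1.2-fold higher number from compound 1 to compound 2 (0.07 log units; within the scatter), with 3-methylphenyl in place of 4-cyclopropylphenyl on an amide-type nitrogen. For the measured compounds named here, no measured compound carries chlorine or fluorine, so this evidence is thin. Going by the values given here, with only that step to go on, no change beyond the scatter is expected in this assay. The estimated change is a 1.1-fold lower number from compound 2 to compound 3 (0.03 log units; within the scatter). For compound 3 the expected value is 13 mL/min/kg, with an estimated range of 7 mL/min/kg to 25 mL/min/kg.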

Compound 3, clearance: 15 mL/min/kg
The estimate for compound 3 lay 1.2-fold (0.06 log units) below the measured number; measured number inside the range.
By their numbers in this assay, from the lowest: compounds 1, 2 and 3 (each within the scatter of the next).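

In this assay, bringing chlorine and fluorine onto the aryl group at this amide-type nitrogen does not move the number beyond the scatter: 3-chloro-4-fluorophenyl in place of 3-methylphenyl gives a 1.1-fold higher number from compound 2 to compound 3 (0.03 log units; within the scatter), and in place of 4-cyclopropylphenyl it gives a 1.3-fold higher number from compound 1 to compound 3 (0.10 log units; within the scatter). The position now carries three differently substituted phenyl groups with every step among them within the scatter, so across these compounds the choice among these three groups does not separate the numbers, and no compound shown goes against this. Nothing available gives a reason for this flat reading.

Going by these compounds, whether the number would hold with an amine or a carboxylic acid on the phenyl group, or with a saturated alkyl chain in place of the phenyl group, stays open. The compounds shown also leave open how far the number depends on the rest of the shared core, which is the same in all of them.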